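Notes on exchanging the (phenylsulfonyl)amino arm of compound 1

This account rests on a few compounds, and the source may have more. Where it says the series, first, only, none or still open, it means among the compounds named here.

Measured so far:
compound 1 `O=S(=O)(NCC1CCN(CCCc2c[nH]c3ccc(-n4cnnc4)cc23)CC1)c1ccccc1`: 6.2 nM
compound 2 `COC[C@H](NC1CCN(CCCc2c[nH]c3ccc(Cn4cncn4)cc23)CC1)c1ccc(F)cc1`: 5 nM
compound 3 `c1ccc(C2CCCCN2C2CCN(CCCc3c[nH]c4ccc(-n5cnnc5)cc34)CC2)cc1`: 1.9 nM

In an assay on CHO cells for displacement of a labelled ligand from 5-hydroxytryptamine receptor 1D (Homo sapiens) (a lower number here means a stronger inhibitor, a higher number a weaker inhibitor), compound 1 stands at the highest number of the three. Compound 2 sits within the scatter of compound 1, so no order between the two can be read. Compound 3 lies beyond the scatter, at the lower number.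

Compound 4 `CN(Cc1ccccc1)CC1CCN(CCCc2c[nH]c3ccc(-n4cnnc4)cc23)CC1` has not yet been run in this assay. It differs from compound 1 in one place: benzyl(methyl)amino in place of (phenylsulfonyl)amino on a saturated chain carbon bound to a saturated ring carbon. Within the data shown here, no measured pair shows this exchange, so the expectation rests on compound 3, which carries no (phenylsulfonyl)amino group and gives 1.9 nM. A modest step toward a lower number is expected, a 1.6-fold lower number from compound 1 to compound 4 (0.19 log units; within the scatter), possibly none beyond the scatter. Compound 4 is estimated at 4 nM, in the range 1.5 nM to 12 nM.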

Compound 4, half-maximal inhibitory concentration: 0.9 nM
Estimate against measurement, compound 4: 4.4-fold (0.65 log units) above; measured number outside the range, below it.
By their numbers in this assay, from the lowest: compound 4; then compound 3; then compounds 2 and 1 (each within the scatter of the next).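

In this assay, the position on a saturated chain carbon bound to a saturated ring carbon accepts a sulfonyl-free arm: benzyl(methyl)amino in place of (phenylsulfonyl)amino gives a 6.9-fold lower number from compound 1 to compound 4 (0.84 log units; beyond the scatter). Neither the sulfonyl group nor the hydrogen-bond donor of compound 1 is required here for a low number, and the six-membered aromatic ring of carbon only is present on both arms. No measurement at hand accounts for the size of this step.

Among these compounds, the exchange alters several features at once, so the one that carries the step remains open. A benzylamino arm, which has no methyl on the nitrogen, would separate the loss of the sulfonyl group from the loss of the donor.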